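From Urea to Amide: Expecting Compound 3

The source may hold more compounds than are shown below. What is called first, only, known or untested is meant among the compounds shown, and "the series" means these compounds.

Compound 2 `COc1cc(-c2nn(-c3ccc(NC(=O)Nc4ccc(Cl)c(C(F)(F)F)c4)cc3)cc2-c2ccncc2)ccc1Cl` carries a urea link between the two aryl parts and gives 1880 nM in a functional assay on SK-MEL-28 cells (Homo sapiens) for antiproliferative activity, read by sulforhodamine B assay, with a stated time of 48 h; a lower number here means a stronger inhibitor, a higher number a weaker inhibitor. For the measured compounds named here, its companion compound 1 `COc1cc(-c2nn(-c3ccc(NC(=O)Nc4ccc(Cl)c(Cl)c4)cc3)cc2-c2ccncc2)ccc1Cl` gives 3940 nM in this assay, so the single measured step is a 2.1-fold lower number from compound 1 to compound 2 (0.32 log units; beyond the scatter). Going by the values given here, on these two numbers compound 2 stands lowest, with compound 1 as its only neighbour at a higher number beyond the scatter.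

Compound 3 `COc1cc(-c2nn(-c3ccc(NC(=O)c4ccc(Cl)c(Cl)c4)cc3)cc2-c2ccncc2)ccc1Cl` is the amide counterpart: 3,4-dichlorophenyl in place of (4-chloro-3-(trifluoromethyl)phenyl)amino on a carbonyl carbon. Two things happen at once. The trifluoromethyl returns to chloro, which on its own would be expected to undo the gain seen from compound 1 to compound 2 and bring the number back toward compound 1. Among the compounds with values here, the loss of the amino linker has no measured precedent here, so its effect is unknown from these data. Taken together, compound 3 is expected to show a higher number than compound 2, most likely at or beyond the level of compound 1, with a wide range: an estimated 8000 nM, between 2500 nM and 25000 nM, corresponding to an expected step of a 4.3-fold higher number from compound 2 to compound 3 (0.63 log units; beyond the scatter).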

Compound 3, half-maximal inhibitory concentration: 40300 nM
Estimate against measurement, compound 3: 5.0-fold (0.70 log units) below, and the stated range ends below it.
By their numbers in this assay, from the lowest: compound 2; then compound 1; then compound 3.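

In this assay, for the compounds shown here, keeping the 3,4-dichlorophenyl group and removing only the amino link on the carbonyl carbon gives a 10-fold higher number from compound 1 to compound 3 (1.01 log units; beyond the scatter) in the one comparison that isolates this link, a large step where the earlier exchange of chloro for trifluoromethyl gave only the modest 2.1-fold lower number from compound 1 to compound 2 (0.32 log units; beyond the scatter) on the urea series. The step of a 21-fold higher number from compound 2 to compound 3 (1.33 log units; beyond the scatter) is also large and places the amide, compound 3, highest of the three numbers, so at this position the urea link counts for more than the difference between the two aryl groups, and the earlier gain does not offset the loss. Nothing available here explains why the number rises so far when the amino link is gone.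

Whether the trifluoromethyl gain seen between the two ureas would also appear on the amide remains open, since compound 3 is the only amide shown and its step cannot be compared with a matching amide partner. Also open, as far as these compounds go, is how the number would respond if a methylene group, or a nitrogen bearing a methyl group, stood in place of the amino link on the carbonyl carbon.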